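The source may hold more compounds than are shown below. What is called first, only, known or untested is meant among the compounds shown, and "the series" means these compounds.

Measured so far:
Compound 1 `CCN(CC)c1cc2[nH]c(C3CCCCC3)nc2cc1NC(=O)c1ccc(N(C)C)cc1`: "not determined" (no result reported)
Compound 2 `O=C(CCc1ccccc1)Nc1cc2nc(C3CCCCC3)[nH]c2cc1N1CCCC1`: > 100 ug/mL

In an ADME assay on Vero cells (Chlorocebus sabaeus) for cytotoxicity, read by resazurin assay, with a stated time of 3 days (a lower number here means a stronger inhibitor, a higher number a weaker inhibitor), compound 1 is recorded as "not determined" (no result reported), so the starting point of this account carries no reading. Compound 2 gives > 100 ug/mL, which is a limit of the assay and not a number. Going by the values given here, that leaves the limit of > 100 ug/mL in this assay, at which 1 of the 2 values shown sits, as the only evidence at hand.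

The next compound, compound 3 `CCCCOC(=O)Nc1cc2nc(C3CCCCC3)[nH]c2cc1N(CC)CC`, keeps the shared core of compound 1, but butoxy replaces 4-(dimethylamino)phenyl on a carbonyl carbon: butoxy in place of 4-(dimethylamino)phenyl on a carbonyl carbon.

Among the compounds with values here, no step between measured compounds is available, so the data cannot size this change in this assay. The expectation is for no step beyond the usual scatter, with neither direction favoured. It rests only on compound 2 at > 100 ug/mL, again a limit. A report of compound 3 as a limit rather than a number would therefore come as no surprise. If a number is obtained, compound 3 is expected to read 100 ug/mL in this assay, with an estimated range of 40 ug/mL to 200 ug/mL.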

Compound 3, half-maximal inhibitory concentration: > 100 ug/mL
Compound 3 gave a limit, no number (the forecaster's own chance of this, stated with the estimate: 65%); the middle value lies on the limit itself.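

Going by these compounds alone, compound 1 carries no reading in this assay and so no step from it to compound 3 can be read. Compound 3 gives > 100 ug/mL as a limit and not a number. The compounds shown leave open how far butoxy in place of 4-(dimethylamino)phenyl moves the reading in this assay and whether either compound would give a number there.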